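Chloro to bromo swap on the aryl ring of compound 1

This account rests on a few compounds, and the source may have more. Where it says the series, first, only, none or still open, it means among the compounds named here.

Measured so far:
compound 1 `CC(c1ccc(-c2ccccc2)c(F)c1)c1nnc2n1N=C(c1ccc(Cl)cc1)CS2` — 7800 nM
compound 2 `CC(C)Cc1ccc(C(C)c2nnc3n2N=C(c2ccc(OC(F)(F)F)cc2)CS3)cc1` — 3000 nM

In a functional assay on HCT-116 cells (Homo sapiens) for inhibition, read by sulforhodamine B assay, with a stated time of 72 h (on this read-out higher numbers stand for weaker inhibition and lower numbers for stronger inhibition), compound 1 gives 7800 nM, the higher of the two numbers in hand. Compound 2 gives 3000 nM in this assay, a lower number that sits beyond the scatter; the two differ in several places, so only the values themselves can be compared. Compound 3 `CC(c1ccc(-c2ccccc2)c(F)c1)c1nnc2n1N=C(c1ccc(Br)cc1)CS2` has not been measured. Its change from compound 1 is bromo in place of chloro on an aromatic carbon. Within the data shown here, no measured pair of this kind exists, so the step of a 1.2-fold lower number from compound 1 to compound 3 (0.08 log units; within the scatter) is expected to be small, with no direction beyond the scatter. Compound 3 is therefore expected to give about 6500 nM in this assay, within 2500 nM to 17000 nM.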

Compound 3, half-maximal inhibitory concentration: 7100 nM
Beside the measured number, compound 3's estimate is 1.1-fold (0.04 log units) below it; measured number inside the range.
By their numbers in this assay, from the lowest: compound 2; then compounds 3 and 1 (each within the scatter of the next).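

In this assay, 4-chlorophenyl to 4-bromophenyl gives a 1.1-fold lower number from compound 1 to compound 3 (0.04 log units; within the scatter) and so leaves the read-out unchanged within the scatter. Among these compounds, this is the first step that isolates a single place, and at this place on the aromatic ring the two halogens cannot be told apart. No measurement in hand offers an explanation for this result.

Still open, on these data alone, is whether a non-halogen group at this place, such as an amine, a carboxylic acid or a methoxy group, would shift the number. Fluoro at this place also remains open.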